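Working notes: from compound 3 to compound 4

The source may hold more compounds than are shown below. What is called first, only, known or untested is meant among the compounds shown, and "the series" means these compounds.

Values in a functional assay on HL-60 cells (Homo sapiens) for antiproliferative activity, read by sulforhodamine B assay, with a stated time of 72 h; on this read-out lower numbers stand for stronger inhibition and higher numbers for weaker inhibition:
- compound 1 `COc1ccccc1NC(=S)N/N=C/c1ccc2ccccc2n1`: 91700 nM
- compound 2 `Cc1cccc(NC(=S)N/N=C/c2ccc3ccccc3n2)c1`: > 100000 nM (a limit)
- compound 3 `NC(=S)N/N=C/c1ccc2ccccc2n1`: > 100000 nM (a limit)

Compound 3 is known only as a limit, > 100000 nM. Compound 2 is likewise known only as a limit, > 100000 nM. The series therefore sits largely at the limit of > 100000 nM in this assay, at which 2 of the 3 values shown sit, and only compound 1 has a number.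

Compound 4 `Cc1ccc(NC(=S)N/N=C/c2ccc3ccccc3n2)cc1` has 4-methylphenyl in place of hydrogen on an amide-type nitrogen, the nitrogen whose other neighbours are the thiocarbonyl carbon: 4-methylphenyl in place of hydrogen on an amide-type nitrogen.

Going by the values given here, three measured steps bear on this change. The closest swaps the same nitrogen between hydrogen and 3-methylphenyl, and it gives a step that the two limits leave unreadable from compound 2 to compound 3. The swap between hydrogen and 2-methoxyphenyl gives an at least 1.0-fold higher number from compound 1 to compound 3 (0.03 log units; that floor lies within the scatter). The swap between the two aryl groups gives an at least 1.0-fold higher number from compound 1 to compound 2 (0.03 log units; that floor lies within the scatter). None of these shows a step beyond the scatter, although the limits leave their true sizes open.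

No step beyond the scatter is therefore expected in this assay, and no direction can be assigned with confidence. The expected step is an at least 1.1-fold lower number from compound 3 to compound 4 (0.04 log units; that floor lies within the scatter). A limit is again a likely outcome. For compound 4 the estimated value is 90000 nM, with an expected range of 40000 nM to 150000 nM.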

Compound 4, half-maximal inhibitory concentration: 78300 nM
Beside the measured number, compound 4's estimate is 1.1-fold (0.06 log units) above it, within the range that was stated.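

In this assay, going by these compounds alone, compound 4 joins compound 1 as the only compounds with a number rather than a limit, which gives this nitrogen its first fully readable comparison of two aryl groups, and those groups are not told apart: a 1.2-fold lower number from compound 1 to compound 4 (0.07 log units; within the scatter). As far as these compounds go, the comparisons with the two limits have floors that are just as small, with an at least 1.2-fold lower number from compound 3 to compound 4 (0.10 log units; that floor lies within the scatter) and an at least 1.2-fold lower number from compound 2 to compound 4 (0.10 log units; that floor lies within the scatter), but their true sizes stay open, so neither shows that 4-methylphenyl differs from hydrogen or from 3-methylphenyl by more than the scatter. The readable values therefore remain in one narrow, weak band, and much of the series still rests on a single assay ceiling: the limit of > 100000 nM in this assay, at which 2 of the 4 values shown sit.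

The compounds shown leave open how far compound 2 and compound 3 really lie from the two measured compounds, since both are known only as limits. They also leave open whether any other group on this nitrogen would give a clearly lower number, such as a benzyl group, a longer alkyl chain, or a phenyl ring carrying an amine or a carboxylic acid.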